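Swapping the Ether Substituent: What to Expect for Compound 3

This account rests on a few compounds, and the source may have more. Where it says the series, first, only, none or still open, it means among the compounds named here.

Among the compounds with values here, compound 2 `Cc1ccc2ccc(-c3cc(C#N)cc(OC(F)(F)F)c3)cc2n1` gives 75 nM in a functional assay on CHO cells for inhibition of metabotropic glutamate receptor 5 (Rattus norvegicus), read by FLIPR and calcium flux (a higher number here means a weaker inhibitor, a lower number a stronger inhibitor), the higher of the two numbers measured so far. Compound 1 `COc1cc(C#N)cc(-c2ccc3ccc(C)nc3c2)c1`, which differs only in carrying methyl rather than trifluoromethyl on the ring oxygen, gives 2.4 nM; the step of a 31-fold higher number from compound 1 to compound 2 (1.49 log units; beyond the scatter). Compound 3 `COCCOc1cc(C#N)cc(-c2ccc3ccc(C)nc3c2)c1` carries 2-methoxyethyl in place of trifluoromethyl on an oxygen on an aromatic ring. Within the data shown here, the single measured step bears on this only indirectly: it shows a large shift when nothing but the group on that oxygen is altered, with trifluoromethyl on the weaker side. Moving away from trifluoromethyl is therefore expected to lower the number, a 7.5-fold lower number from compound 2 to compound 3 (0.88 log units; beyond the scatter), although the longer chain itself is untested. Compound 3 is estimated at 10 nM, within a range of 2 nM to 50 nM.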

Compound 3, half-maximal inhibitory concentration: 82 nM
The estimate for compound 3 lay 8.2-fold (0.91 log units) below the measured number; measured number above the stated range.
By their numbers in this assay, from the lowest: compound 1; then compounds 2 and 3 (each within the scatter of the next).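

Putting 2-methoxyethyl rather than trifluoromethyl on this oxygen gives a number that cannot be told apart, a 1.1-fold higher number from compound 2 to compound 3 (0.04 log units; within the scatter). Extending the methyl with methoxymethyl also gives a large step, a 34-fold higher number from compound 1 to compound 3 (1.53 log units; beyond the scatter), so trifluoromethyl is not the only group here that sits far from methyl. Nothing available explains why these two different groups give such similar numbers.

From the compounds shown here alone, it remains open whether a shorter chain such as ethyl stays close to compound 1 or already shows the large step. Going by these compounds, the effect of an amine at the end of the chain is also open.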